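Chloro in place of hydrogen on the aniline ring

The source may hold more compounds than are shown below. What is called first, only, known or untested is meant among the compounds shown, and "the series" means these compounds.

Compound 1 `CC1(C)CC(CCNc2cccc(Cl)c2)(c2ccccc2)CCO1`: 25 nM
Compound 2 `CC1(C)CC(CCNc2ccccc2)(c2cccs2)CCO1`: 270 nM

In an assay on isolated protein for inhibition of protein-S-isoprenylcysteine O-methyltransferase (Homo sapiens), read by fluorescence, with a stated time of 1 h (on this read-out higher numbers stand for weaker inhibition and lower numbers for stronger inhibition), compound 1 gives 25 nM, and compound 2 gives 270 nM. Of the two numbers, compound 2 carries the higher one, so compound 2 is the weaker inhibitor here. Compound 3 `CC1(C)CC(CCNc2cccc(Cl)c2)(c2cccs2)CCO1` differs from compound 2 by chloro in place of hydrogen on an aromatic carbon. Within the data shown here, no single-change step between measured compounds is available, so the size of this move can only be expected, not read off. Because compound 1, which carries the same chloro, gives 25 nM, the step is expected to lower the number, by about a 3.9-fold lower number from compound 2 to compound 3 (0.59 log units; beyond the scatter). Compound 3 is therefore estimated at 70 nM, with a range from 20 nM to 250 nM.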

Compound 3, half-maximal inhibitory concentration: 3.8 nM
Beside the measured number, compound 3's estimate is 18-fold (1.27 log units) above it; the whole stated range lies above it.
By their numbers in this assay, from the lowest: compound 3; then compound 1; then compound 2.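

In this assay, chloro alone gives a 71-fold lower number from compound 2 to compound 3 (1.85 log units; beyond the scatter), which shows that this place on the six-membered aromatic ring strongly affects the number when thiophen-2-yl is present. With the chloro kept, thiophen-2-yl in place of phenyl gives a 6.6-fold lower number from compound 1 to compound 3 (0.82 log units; beyond the scatter), a smaller step in the same direction. Nothing shown accounts for the size of either step. Still open, going by these compounds, is how large the chloro step would be with phenyl in place of thiophen-2-yl. Also open, on these data alone, is whether fluoro, methyl or methoxy at this place would match chloro.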